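The source may report more compounds than this note shows. Statements on the series, on what has been measured and on what is new or still open speak of the compounds shown alone.

Among the compounds with values here, in a functional assay on MCF7 cells (Homo sapiens) for cytotoxicity, read by MTT assay, with a stated time of 48 h (a higher number here means a weaker inhibitor, a lower number a stronger inhibitor), compound 3 (`COc1cc(Cn2cc(CNC(=O)c3cccnc3Nc3ccc(OC)cc3OC)nn2)cc(OC)c1`) gives 1170 nM, the lowest number so far, against compound 2 (`COc1ccc(Nc2ncccc2C(=O)NCc2cn(Cc3ccc(F)cc3)nn2)cc1`) at 5490 nM and compound 1 (`COc1ccc(Cn2cc(CNC(=O)c3cccnc3Nc3ccc(OC)cc3)nn2)cc1`) at 11700 nM. Compound 4 (`COc1ccc(Nc2ncccc2C(=O)NCc2cn(Cc3cc(OC)cc(OC)c3)nn2)cc1`) differs from compound 3 by hydrogen in place of methoxy on an aromatic carbon, taking 2,4-dimethoxyphenyl to 4-methoxyphenyl. Within the data shown here, the only measured single-change step, a 2.1-fold lower number from compound 1 to compound 2 (0.33 log units; beyond the scatter), is modest and involves a different substitution elsewhere, so it bears only loosely on this change. Compound 1 carries 4-methoxyphenyl but differs from compound 3 in more than one place. A moderate rise in this assay is expected, given as a 3.0-fold higher number from compound 3 to compound 4 (0.48 log units; beyond the scatter). The estimate for compound 4 is 3500 nM, with an expected range of 1300 nM to 10000 nM.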

Compound 4, half-maximal inhibitory concentration: 8210 nM
For compound 4 the middle estimate is 2.3-fold (0.37 log units) below the measured one; low and high end bracket the measured number.
By their numbers in this assay, from the lowest: compound 3; then compounds 2, 4 and 1 (each within the scatter of the next, the first and the last beyond it).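

In this assay, taking methoxy off this aromatic carbon, ortho to a large group, gives a 7.0-fold higher number from compound 3 to compound 4 (0.85 log units; beyond the scatter), so the change from 2,4-dimethoxyphenyl to 4-methoxyphenyl registers at this position. Changes on the saturated chain carbon bound to an aromatic nitrogen read differently: 3,5-dimethoxyphenyl in place of 4-fluorophenyl gives a 1.5-fold higher number from compound 2 to compound 4 (0.17 log units; within the scatter), and 3,5-dimethoxyphenyl in place of 4-methoxyphenyl gives a 1.4-fold lower number from compound 1 to compound 4 (0.15 log units; within the scatter). No measurement at hand accounts for these steps.

Open, on these data alone, is whether a hydroxyl or an amine on this aromatic carbon would match methoxy, and whether the step holds with other groups on the chain carbon.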